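A few compounds are considered here, and "the series" means these few. Any claim that something is new, unique, unknown or untested is made for them only; others in the source may bear on it.

Compound 3 `Cc1ccccc1C(=O)Nc1nnc(-c2ccc(Cl)cc2)s1` gives 158 nM in a functional assay on the whole organism (integument) for inhibition, with Chilo suppressalis as the target, read by scintillation counting, with a stated time of 72 h (a lower number here means a stronger inhibitor, a higher number a weaker inhibitor), the highest of the two numbers recorded there. Compound 1 `COc1cccc(OC)c1C(=O)Nc1nnc(-c2ccc(Cl)cc2)s1` gives 58.9 nM in this assay, a lower number beyond the scatter. Compound 2 `O=C(Nc1nnc(-c2ccc(Cl)cc2)s1)c1ccccc1I` yields only a limit in this assay, > 5010 nM. Within the data shown here, the one measured step, an at least 31-fold lower number from compound 2 to compound 3 (1.50 log units; beyond the scatter), concerns iodo and methyl and therefore bears only loosely on the change now at hand. Compound 4 `COc1ccccc1C(=O)Nc1nnc(-c2ccc(Cl)cc2)s1` differs from compound 3 by methoxy in place of methyl on an aromatic carbon. Since compound 1 carries two methoxy groups and gives 58.9 nM, a modest lowering is expected, a 1.8-fold lower number from compound 3 to compound 4 (0.24 log units; within the scatter). Compound 4 is therefore estimated at 90 nM in this assay, within a range from 30 nM to 300 nM.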

Compound 4, half-maximal inhibitory concentration: 53.7 nM
Estimate against measurement, compound 4: 1.7-fold (0.22 log units) above; the measured number falls inside the stated range.
By their numbers in this assay, from the lowest: compounds 4 and 1 (each within the scatter of the next); then compound 3. At a limit, above all of these: compound 2.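

Ortho to a large group, methoxy in place of methyl gives a 2.9-fold lower number from compound 3 to compound 4 (0.47 log units; beyond the scatter) and so a single methoxy is enough to move the number. Hydrogen in place of methoxy gives a 1.1-fold lower number from compound 1 to compound 4 (0.04 log units; within the scatter) and leaves no readable difference, so the second methoxy of compound 1 adds nothing that can be seen here. Compound 2 stands at a limit, so an at least 93-fold lower number from compound 2 to compound 4 (1.96 log units; beyond the scatter) is a bound and not a size: the limit of > 5010 nM in this assay, at which 1 of the 4 values shown sits. The compounds shown leave open how a hydroxy group, an amine or a longer chain such as ethoxy would behave at this position.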